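A few compounds are considered here, and "the series" means these few. Any claim that something is new, unique, unknown or untested is made for them only; others in the source may bear on it.

In a functional assay on HCT-116 cells (Homo sapiens) for inhibition, read by ELISA, with a stated time of 24 h (a lower number here means a stronger inhibitor of growth, a higher number a weaker inhibitor of growth), compound 1 `CO/N=C/C=C/c1ccccc1OC(=O)c1ccccc1` gives > 100000 nM, and this value is a limit of the assay, not a number. Among the measured compounds shown here, compound 2 `CN1CCN(C(=O)ONC(=O)/C=C/c2ccccc2OC(=O)c2ccccc2)CC1` gives 40400 nM, the only actual number so far. Compound 3 `CC(=O)ONC(=O)/C=C/c1ccccc1OC(=O)c1ccccc1` carries methyl in place of 4-methylpiperazin-1-yl on a carbonyl carbon. For the measured compounds named here, no measured pair of compounds shows what this change does, so no step beyond the usual scatter is expected, in either direction. The expected change is small, an estimated 1.2-fold lower number from compound 2 to compound 3 (0.06 log units; within the scatter). For compound 3 the estimated value is 35000 nM, with an expected range of 9000 nM to 100000 nM.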

Compound 3, concentration for 50% growth inhibition: 21300 nM
Compound 3: the middle estimate sits 1.6-fold (0.22 log units) above what was measured; the range from low to high includes it.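

In this assay, methyl in place of 4-methylpiperazin-1-yl on the carbonyl carbon gives a 1.9-fold lower number from compound 2 to compound 3 (0.28 log units; within the scatter), so the growth inhibition seen with compound 2 does not depend on the 4-methylpiperazin-1-yl group. The group on the double-bonded chain carbon does matter: an at least 4.6-fold lower number from compound 1 to compound 3 (0.67 log units; beyond the scatter). That step rests on compound 1, whose value is a limit and not a number: the limit of > 100000 nM in this assay, at which 1 of the 3 values shown sits.

Compound 3 gives 21300 nM. From the compounds shown here alone, whether an amine or a longer chain such as propyl on this carbonyl carbon would move that number by more than the scatter remains open.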